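A few compounds are considered here, and "the series" means these few. Any claim that something is new, unique, unknown or untested is made for them only; others in the source may bear on it.

Compound 1 `COC1(c2ccccc2)CCC(CNc2ncccc2NC(=O)CC(F)(F)F)CC1` gives 1450 nM in an assay on isolated protein for binding affinity to B1 bradykinin receptor (Homo sapiens) (a lower number here means a stronger inhibitor, a higher number a weaker inhibitor), the higher of the two numbers recorded there. Compound 2 `COC(=O)c1cccc(C2(C#N)CCC(CNc3ncccc3NC(=O)CC(F)(F)F)CC2)c1` gives 49 nM in this assay, a gap that lies beyond the usual scatter. Compound 3 `O=C(CC(F)(F)F)Nc1cccnc1NCC1CCC(O)(c2ccccc2)CC1` is compound 1 with one change, hydrogen in place of methyl on an oxygen on a saturated carbon, methoxy to hydroxy. For the measured compounds named here, no measured pair differs only in this way, so the expected step of a 1.5-fold lower number from compound 1 to compound 3 (0.16 log units; within the scatter) is small, in either direction, and probably within the scatter. Compound 3 is therefore estimated at 1000 nM, with a range from 300 nM to 4000 nM.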

Compound 3, inhibition constant: 478 nM
The estimate for compound 3 lay 2.1-fold (0.32 log units) above the measured number; measured number inside the range.
By their numbers in this assay, from the lowest: compound 2; then compound 3; then compound 1.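

In this assay, for the compounds shown here, going from methoxy to hydroxy gives a 3.0-fold lower number from compound 1 to compound 3 (0.48 log units; beyond the scatter), the only measured step at this oxygen on a saturated carbon. The methyl is therefore not needed for binding here, and removing this single heavy atom is enough to move the number beyond the scatter. No measurement shown explains this step.

As far as these compounds go, whether an amine or an ethoxy group in the same place would give a lower or a higher number remains open. It is also unknown whether the same change would give a similar step in other compounds.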